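From 4-Nitrophenyl to 3-Fluorophenyl on an Amide-Type Nitrogen

The source may report more compounds than this note shows. Statements on the series, on what has been measured and on what is new or still open speak of the compounds shown alone.

Compound 1 `COc1cc(N(C)C(=O)N(C)c2ccc([N+](=O)[O-])cc2)cc(OC)c1OC`: >= 125000 nM
Compound 2 `COc1cc(N(C)C(=O)c2cccc([N+](=O)[O-])c2)cc(OC)c1OC`: >= 125000 nM

Both measured compounds were examined in a functional assay on ONS-76 cells (Homo sapiens) for cytotoxicity, read by MTT assay, with a stated time of 72 h; a higher number here means a weaker inhibitor, a lower number a stronger inhibitor. Compound 1 reaches only the limit of the assay, >= 125000 nM. Compound 2 likewise gives only a limit, >= 125000 nM. Where compound 1 stands is therefore fixed only as a limit, and the one further value shown is a limit as well; the limit of >= 125000 nM in this assay, at which 2 of the 2 values shown sit, sums this up. Within the data shown here, no step between measured compounds that differ in one place is available. Compound 3 `COc1cc(N(C)C(=O)N(C)c2cccc(F)c2)cc(OC)c1OC` has not yet been measured in this assay. It differs from compound 1 in one place: 3-fluorophenyl in place of 4-nitrophenyl on an amide-type nitrogen. With both known values sitting at the limit, the change from compound 1 to compound 3 offers no measured direction to build on, and a step of no size beyond the scatter is expected, a number no higher from compound 1 to compound 3 (the limit leaves the size open). Compound 3 is accordingly estimated at 125000 nM, within a range from 40000 nM to 300000 nM, and is expected most likely to be reported again only as a limit.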

Compound 3, half-maximal inhibitory concentration: >= 125000 nM
Compound 3 ended at the assay's limit; the forecaster's own chance of this, stated with the estimate: 80%; the middle value lies on the limit itself.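

Compound 1 and compound 3 both rest at a limit, so no step can be read between them: the limit of >= 125000 nM in this assay, at which 3 of the 3 values shown sit. The compounds shown leave open what number any of them would reach, and whether any group on the amide-type nitrogen gives a value short of the limit.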